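The source may report more compounds than this note shows. Statements on the series, on what has been measured and on what is new or still open speak of the compounds shown alone.

Three compounds sharing a long acylated chain were examined in a functional assay on KB cells (Homo sapiens) for inhibition, read by MTT assay, with a stated time of 24 h, tested at 1 ug/mL; a lower number here means less inhibition of growth, a higher number more inhibition of growth at the concentration tested. Compound 1, with the structure `CC(=O)SCCC(CCCCC(=O)Nc1cccc(Cl)c1)SC(C)=O`, gives 0.04% in this assay. Compound 2, `CC(=O)SCCC(CCCCC(=O)Nc1ccc(Cl)cc1)SC(C)=O`, differs from it only by 4-chlorophenyl in place of 3-chlorophenyl on an amide-type nitrogen, and in this assay compound 2 gives 14.8%, a change of a number 14.8 percentage points higher from compound 1 to compound 2 (beyond the scatter). Compound 3, `O=C(CCCCC(CCSC(=O)c1ccccc1)SC(=O)c1ccccc1)Nc1cccc(Cl)c1`, carries benzoyl groups on both sulfur atoms where compounds 1 and 2 carry acetyl groups; the difference between the core of compound 1 and the core of compound 3 is not broken down here. In this assay compound 3 gives 12.7%, which is within the scatter of the value of compound 2 and beyond the scatter above the value of compound 1.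

Compound 4, `O=C(CCCCC(CCSC(=O)c1ccccc1)SC(=O)c1ccccc1)Nc1ccc(Cl)cc1`, has not yet been measured in this assay. It stands to compound 3 as compound 2 stands to compound 1: the change is 4-chlorophenyl in place of 3-chlorophenyl on an amide-type nitrogen, at the same place on the same amide-type nitrogen, so it is the same change as before. Within the data shown here, the only guide to what this change does is the one step from compound 1 to compound 2, and because that step was a number 14.8 percentage points higher from compound 1 to compound 2 (beyond the scatter) a rise of similar size is expected here, giving an estimated a number 13.3 percentage points higher from compound 3 to compound 4 (beyond the scatter). Compound 4 is therefore estimated at 26% in this assay, with a range from 10% to 45%, the wide span reflecting that the expectation rests on a single pair.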

Compound 4, percent growth inhibition at one concentration: 11.7%
Compound 4: middle estimate off by 14.3 percentage points, on the high side; low and high end bracket the measured number.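

In this assay, the change to 4-chlorophenyl in place of 3-chlorophenyl on the amide-type nitrogen did not repeat its effect when carried from the acetyl-bearing compounds to the benzoyl-bearing ones, the new step being a number 1 percentage points lower from compound 3 to compound 4 (within the scatter). The two steps therefore differ, so the effect of this change in the series depends on the core that carries it, and a step seen on one core cannot simply be transferred to the other: the same change on two cores in this assay, a number 14.8 percentage points higher (beyond the scatter) from compound 1 to compound 2 and a number 1 percentage points lower (within the scatter) from compound 3 to compound 4, 15.8 percentage points apart, beyond the scatter of two such steps

Among these compounds, this comparison does not show why the two cores behave differently, and with only one pair on each core it gives no rule for how the change would behave on any further core. The compounds shown carry only a chlorine on the phenyl ring and only acetyl or benzoyl groups on the sulfur atoms, all on a single chain. On these data alone, it remains open whether a plain phenyl, a methoxyphenyl, a propionyl group on the sulfur atoms or a longer chain would follow the pattern of the acetyl pair, that of the benzoyl pair, or neither.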